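A few compounds are considered here, and "the series" means these few. Any claim that something is new, unique, unknown or untested is made for them only; others in the source may bear on it.

Compound 1 `CC(/N=c1\c(O)c(O)\c1=N/c1ccc(S(N)(=O)=O)cc1)C(C)(C)C`, compound 2 `CC(/N=c1\c(O)c(O)\c1=N/c1ccc(C#N)cc1)C(C)(C)C` and compound 3 `CC(=O)c1ccc(/N=c2\c(O)c(O)\c2=N/C(C)C(C)(C)C)cc1` share a core and a 1,2,2-trimethylpropyl group, and they differ only in the group on an aromatic carbon. All three were tested in a functional assay for inhibition, with Rattus norvegicus as the target; a lower number here means a stronger inhibitor, a higher number a weaker inhibitor. Compound 1 reaches only a limit of the assay, > 30000 nM. Compound 3 reads 21200 nM, while compound 2 reads 520 nM, the lowest number of the set.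

Cyano in place of sulfamoyl gives an at least 57-fold lower number from compound 1 to compound 2 (1.76 log units; beyond the scatter), and acetyl in place of cyano gives a 41-fold higher number from compound 2 to compound 3 (1.61 log units; beyond the scatter). Acetyl in place of sulfamoyl gives an at least 1.4-fold lower number from compound 1 to compound 3 (0.15 log units; that floor lies within the scatter), a floor that says little.

Compound 4 `CCCCCCC/N=c1\c(O)c(O)\c1=N/c1ccc(C#N)cc1` keeps the cyano group of compound 2 but has heptyl in place of 1,2,2-trimethylpropyl on a double-bonded nitrogen. Among the compounds with values here, none of the measured steps touches that place, so they bear on it only indirectly, showing that single changes in this set can be large in this assay. Within the data shown here, compound 2 at 520 nM is the best value so far, so a moderate rise is expected rather than a fall, though with wide uncertainty. The estimated change is a 4.8-fold higher number from compound 2 to compound 4 (0.68 log units; beyond the scatter). For compound 4 the expected value is 2500 nM, with an estimated range of 400 nM to 15000 nM.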

Compound 4, half-maximal inhibitory concentration: > 30000 nM
Compound 4: only a limit was reported; the forecaster's own chance of this, stated with the estimate: 8%; at least 12-fold (1.07 log units) between middle value and limit.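

Until compound 4, every step in this assay concerned the group on an aromatic carbon, while the double-bonded nitrogen carried 1,2,2-trimethylpropyl throughout. Heptyl in place of 1,2,2-trimethylpropyl on that nitrogen gives an at least 57-fold higher number from compound 2 to compound 4 (1.76 log units; beyond the scatter), so this place can also carry a large step, even though both groups are all-carbon, have no ring and have no hydrogen-bond donors or acceptors. Compound 4 gives only a limit of the assay, > 30000 nM, so the step is a floor and its full size stays unknown: the limit of > 30000 nM in this assay, at which 2 of the 4 values shown sit.

The compounds shown leave open whether a shorter straight chain such as propyl, a compact branched group such as tert-butyl, a ring such as cyclohexyl or a chain ending in an amine on that nitrogen would keep a number close to that of compound 2. They also leave open whether heptyl has the same consequence when acetyl or sulfamoyl, rather than cyano, sits on the aromatic carbon.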